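A few compounds are considered here, and "the series" means these few. Any claim that something is new, unique, unknown or untested is made for them only; others in the source may bear on it.

Working notes on the series in a functional assay on A-375 cells (Homo sapiens) for cytotoxicity, read by MTT assay, with a stated time of 48 h; on this read-out lower numbers stand for stronger inhibition and higher numbers for weaker inhibition.

Three compounds share one core and differ only in the aryl group on the carbonyl carbon of the side chain. Compound 1 `CC1(C)S[C@@H]2/C(=C\C(=O)c3ccccc3)C(=O)N2[C@H]1C(=O)OC(c1ccccc1)c1ccccc1` gives 22800 nM. Compound 2 `CC1(C)S[C@@H]2/C(=C\C(=O)c3ccc(Br)cc3)C(=O)N2[C@H]1C(=O)OC(c1ccccc1)c1ccccc1` gives 29700 nM. Compound 3 `CC1(C)S[C@@H]2/C(=C\C(=O)c3ccc4ccccc4c3)C(=O)N2[C@H]1C(=O)OC(c1ccccc1)c1ccccc1` gives 36500 nM. The three steps are all small: a 1.3-fold higher number from compound 1 to compound 2 (0.11 log units; within the scatter), a 1.6-fold higher number from compound 1 to compound 3 (0.20 log units; within the scatter) and a 1.2-fold higher number from compound 2 to compound 3 (0.09 log units; within the scatter). Compound 3 therefore stands at the top of the three numbers, but its separation from compound 2 and from compound 1 is within the scatter, so no ordering among the three can be read from these values.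

Compound 4 `CC1(C)S[C@@H]2/C(=C\C(=O)c3ccco3)C(=O)N2[C@H]1C(=O)OC(c1ccccc1)c1ccccc1` is the next member. Relative to compound 3 the change is furan-2-yl in place of naphthalen-2-yl on a carbonyl carbon. Among the measured compounds shown here, the steps that bear on this position are the two earlier exchanges at the same carbonyl carbon, a 1.6-fold higher number from compound 1 to compound 3 (0.20 log units; within the scatter) and a 1.2-fold higher number from compound 2 to compound 3 (0.09 log units; within the scatter), and neither moved the number beyond the scatter. For the measured compounds named here, nothing measured so far involves a five-membered ring at this place, so the expectation rests only on the flatness seen across phenyl, 4-bromophenyl and naphthalen-2-yl. For compound 4 the expected step is a 1.2-fold lower number from compound 3 to compound 4 (0.09 log units; within the scatter), that is, no change beyond the scatter. Compound 4 is accordingly estimated at 30000 nM, with a range of 12000 nM to 75000 nM.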

Compound 4, half-maximal inhibitory concentration: 26000 nM
For compound 4 the middle estimate is 1.2-fold (0.06 log units) above the measured one; low and high end bracket the measured number.
By their numbers in this assay, from the lowest: compounds 1, 4, 2 and 3 (each within the scatter of the next).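

In this assay, furan-2-yl on the carbonyl carbon gives a 1.4-fold lower number from compound 3 to compound 4 (0.15 log units; within the scatter), a 1.1-fold lower number from compound 2 to compound 4 (0.06 log units; within the scatter) and a 1.1-fold higher number from compound 1 to compound 4 (0.06 log units; within the scatter), all within the scatter. Among the compounds shown here, this extends the flat picture at this position to a five-membered aromatic ring with 1 hetero atom and 1 hydrogen-bond acceptor, and to a group of 5 heavy atoms in place of naphthalen-2-yl, with no compound of the four going against it. No measurement on hand offers an explanation for this flatness.

The compounds shown leave open whether a non-aromatic group at this carbonyl carbon, such as an aminoethyl chain or a simple methyl, would move the number beyond the scatter. They also leave open what a free carboxylic acid in place of the diphenylmethyl ester on the shared core would do.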